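Phenoxymethyl to Phenoxy: Expected Potency of Compound 4

The source may hold more compounds than are shown below. What is called first, only, known or untested is meant among the compounds shown, and "the series" means these compounds.

Compound 3 `COC(=O)c1ccc(-c2cnc(C(=O)CCc3ccc(COc4ccccc4)cc3)o2)nc1` gives 3.5 nM in an assay for inhibition of Fatty-acid amide hydrolase 1 (Rattus norvegicus) (on this read-out higher numbers stand for weaker inhibition and lower numbers for stronger inhibition), the second highest of the three numbers shown. Compound 1 `NC(=O)c1cnc(C(=O)CCc2ccc(Oc3ccccc3)cc2)o1` gives 6.6 nM, within the scatter of compound 3, while compound 2 `N#Cc1cnc(C(=O)CCc2ccc(Oc3ccccc3)cc2)o1` gives 0.8 nM, beyond the scatter below compound 3. Compound 4 `COC(=O)c1ccc(-c2cnc(C(=O)CCc3ccc(Oc4ccccc4)cc3)o2)nc1` differs from compound 3 in one place: phenoxy in place of phenoxymethyl on an aromatic carbon. Within the data shown here, the only measured step, an 8.3-fold lower number from compound 1 to compound 2 (0.92 log units; beyond the scatter), concerns a different position and does not bear on this change; no measured pair isolates the phenoxymethyl-to-phenoxy exchange. Compounds 1 and 2 both carry the phenoxy group, and compound 2 lies beyond the scatter below compound 3, so a small move toward lower numbers, a 1.4-fold lower number from compound 3 to compound 4 (0.15 log units; within the scatter), is expected but not one clearly beyond the scatter. Compound 4 is therefore estimated at 2.5 nM, with a range from 0.7 nM to 9 nM.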

Compound 4, inhibition constant: 54 nM
Compound 4: the middle estimate sits 22-fold (1.33 log units) below what was measured; measured number outside the range, above it.
By their numbers in this assay, from the lowest: compound 2; then compounds 3 and 1 (each within the scatter of the next); then compound 4.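

In this assay, the aromatic carbon bearing this group is far from indifferent: with 5-(methoxycarbonyl)pyridin-2-yl on the core, phenoxy in place of phenoxymethyl costs heavily (a 15-fold higher number from compound 3 to compound 4 (1.19 log units; beyond the scatter)). Phenoxy alone therefore does not secure low numbers, as that same pyridinyl group also gives higher numbers than cyano (a 68-fold higher number from compound 2 to compound 4 (1.83 log units; beyond the scatter)) and carbamoyl (an 8.2-fold higher number from compound 1 to compound 4 (0.91 log units; beyond the scatter)). No evidence shown accounts for these steps.

From the compounds shown here alone, whether phenoxymethyl would give the same gain alongside cyano or carbamoyl remains open. So does the outcome with a longer link, such as phenoxyethyl, or with a benzyl group.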